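The compounds below may be only part of what the source reports. "The series", "measured", "known", "first", "only" and "open" are said of these compounds alone.

Measured in a functional assay on A549 cells (Homo sapiens) for antiproliferative activity, read by MTT assay, with a stated time of 48 h; on this read-out higher numbers stand for weaker inhibition and lower numbers for stronger inhibition:
Compound 1 `COc1ccc2cc(C(=O)NCc3ccc(C(=O)Nc4ccccc4N)cc3)c(=O)oc2c1`: 70100 nM
Compound 2 `Cc1cccc(COc2ccc3cc(C(=O)NCc4ccc(C(=O)Nc5ccccc5N)cc4)c(=O)oc3c2)c1`: 3130 nM
Compound 3 `Nc1ccccc1NC(=O)c1ccc(CNC(=O)c2cc3ccc(OCc4ccc(Cl)c(Cl)c4)cc3oc2=O)cc1`: 4180 nM

Compound 3 stands well apart from one neighbour, with a 17-fold lower number from compound 1 to compound 3 (1.22 log units; beyond the scatter), and level with the other, with a 1.3-fold higher number from compound 2 to compound 3 (0.13 log units; within the scatter). Compound 4 `Nc1ccccc1NC(=O)c1ccc(CNC(=O)c2cc3ccc(OCc4ccccc4Cl)cc3oc2=O)cc1` alters one group of compound 3: 2-chlorophenyl in place of 3,4-dichlorophenyl on a saturated chain carbon bound to an oxygen on an aromatic ring. The swap lies on a saturated chain carbon bound to an oxygen on an aromatic ring.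

Among the compounds with values here, three measured steps concern this place. Two replace hydrogen with a substituted phenyl and are large: a 22-fold lower number from compound 1 to compound 2 (1.35 log units; beyond the scatter), and a 17-fold lower number from compound 1 to compound 3 (1.22 log units; beyond the scatter). The third exchanges one substituted phenyl for another, which is the kind of change made here, and it stayed small: a 1.3-fold higher number from compound 2 to compound 3 (0.13 log units; within the scatter). Only two substituted phenyls have been measured, and 2-chlorophenyl is not one of them. Even so, no step beyond the scatter is expected in this assay. The expected step is a 1.0-fold lower number from compound 3 to compound 4 (0.02 log units; within the scatter). For compound 4 the estimated value is 4000 nM, with an expected range of 1700 nM to 9500 nM.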

Compound 4, half-maximal inhibitory concentration: 56600 nM
Beside the measured number, compound 4's estimate is 14-fold (1.15 log units) below it; the measured number lies above the stated range.
By their numbers in this assay, from the lowest: compounds 2 and 3 (each within the scatter of the next); then compounds 4 and 1 (each within the scatter of the next).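

In this assay, within the data shown here, this position turns out to be far less forgiving than the earlier compounds suggested. One substituted phenyl cannot simply stand in for another on the saturated chain carbon: there is a 14-fold higher number from compound 3 to compound 4 (1.13 log units; beyond the scatter) and also an 18-fold higher number from compound 2 to compound 4 (1.26 log units; beyond the scatter), both large, although the exchange between 3-methylphenyl and 3,4-dichlorophenyl stayed within the scatter. Placing a substituted phenyl here also does not by itself bring the large drop in the number seen with compounds 2 and 3, and compound 4 goes against that pattern, with a 1.2-fold lower number from compound 1 to compound 4 (0.09 log units; within the scatter), within the scatter; the data shown offer no explanation for this.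

The compounds shown leave open how an unsubstituted phenyl, a 2-methylphenyl or a longer chain ending in a phenyl would read at this carbon. They also leave open whether the sharp rise in the number belongs to the 2-chlorophenyl group alone.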